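The source may report more compounds than this note shows. Statements on the series, on what has been measured and on what is new or still open speak of the compounds shown alone.

Series on a shared core, `CC(C)(O)c1cn(CC(=O)NCc2ccccc2)nn1` for compound 1. In an ADME assay on cells (spleen, Mus musculus, strain C57BL/6) for inhibition, read by flow cytometry and propidium iodide staining, with a stated time of 24 h, at 37 degrees C (on this read-out higher numbers stand for an effect only at larger amounts of compound and lower numbers for an effect already at smaller amounts), compound 1 gives 1600 uM. Compound 2, `O=C(O)CCCCc1cn(CC(=O)NCc2ccccc2)nn1`, gives 1080 uM in this assay; compound 3, `O=C(Cn1cc(-c2ccccc2[N+](=O)[O-])nn1)NCc1ccccc1`, is recorded in this assay as "non-toxic" (no number reported) without a single number. Of the two numbers, compound 2 holds the smaller, with compound 1 nearest at a 1.5-fold lower number from compound 1 to compound 2 (0.17 log units; within the scatter), so the two are not separated. Compound 4, `COc1cccc(-c2cn(CC(=O)NCc3ccccc3)nn2)c1`, is to be measured in this assay; it differs from compound 2 by 3-methoxyphenyl in place of 4-carboxybutyl on an aromatic carbon. For the measured compounds named here, the one measured step, a 1.5-fold lower number from compound 1 to compound 2 (0.17 log units; within the scatter), exchanges one non-ring group for another on the same aromatic carbon and lies within the scatter; no measured step brings an aromatic ring onto that carbon, and compound 3, the one entry with such a ring, has no number. The step from compound 2 to compound 4 is therefore expected to be a 1.2-fold higher number from compound 2 to compound 4 (0.08 log units; within the scatter), not beyond the scatter. Compound 4 is estimated at 1300 uM, between 500 uM and 3000 uM.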

Compound 4, concentration for half-maximal effect: 840 uM
Estimate against measurement, compound 4: 1.5-fold (0.19 log units) above; low and high end bracket the measured number.
By their numbers in this assay, from the lowest: compounds 4, 2 and 1 (each within the scatter of the next).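

In this assay, an aromatic ring on this carbon now carries a number: a 1.3-fold lower number from compound 2 to compound 4 (0.11 log units; within the scatter), and a 1.9-fold lower number from compound 1 to compound 4 (0.28 log units; within the scatter). Exchanging either non-ring group for 3-methoxyphenyl, a six-membered aromatic ring of carbon only, therefore leaves compound 4 unseparated from both. No measurement bearing on the cause of these steps is available.

Going by these compounds, whether an amine or a longer chain on this aromatic carbon would give a step beyond the scatter remains open. Compound 3 has no single number, so its ring cannot be set against that of compound 4.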